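A few compounds are considered here, and "the series" means these few. Any claim that something is new, unique, unknown or untested is made for them only; others in the source may bear on it.

Measured in an ADME assay on microsomes from liver (Homo sapiens) for metabolic stability; on this read-out lower numbers stand for slow clearance and higher numbers for fast clearance:

- compound 1 `CCc1ccc(-c2c(-c3nn(C)c4ncnc(N5CC(NC(=O)OC)C5)c34)cnn2C)cc1`: 42 mL/min/kg
- compound 2 `Cc1ccc(-c2c(-c3nn(C)c4ncnc(N5CCC5)c34)cnn2C)cc1`: 47 mL/min/kg
- compound 3 `CC(C)Cc1nn(C)c2ncnc(N3Cc4ccccc4C3)c12`: 123 mL/min/kg

Compound 2 stands close to compound 1, as the two values lie within the scatter of each other. Compound 3 gives a clearly higher number, beyond the scatter, which leaves compound 2 in the lower part of this small range.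

Compound 4 `Cn1ncc(-c2nn(C)c3ncnc(N4CCC4)c23)c1-c1ccc(C2CC2)cn1` has not yet been measured. It departs from compound 2 in one place, on an aromatic carbon of a five-membered aromatic ring with 2 nitrogen: 5-cyclopropylpyridin-2-yl in place of 4-methylphenyl on an aromatic carbon. For the measured compounds named here, no measured pair here differs in one place only, so the size of this change can only be judged indirectly. Compound 1 differs from compound 2 in more than one place, yet compound 1 gives 42 mL/min/kg and compound 2 gives 47 mL/min/kg. On that basis, no step beyond the scatter is expected in this assay. The expected size is a 1.2-fold lower number from compound 2 to compound 4 (0.07 log units; within the scatter). For compound 4 the estimated clearance is 40 mL/min/kg, with an expected range of 22 mL/min/kg to 75 mL/min/kg.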

Compound 4, clearance: 53 mL/min/kg
Compound 4: the middle estimate sits 1.3-fold (0.12 log units) below what was measured; the range from low to high includes it.
By their numbers in this assay, from the lowest: compounds 1, 2 and 4 (each within the scatter of the next); then compound 3.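

In this assay, for the compounds shown here, 5-cyclopropylpyridin-2-yl in place of 4-methylphenyl on an aromatic carbon gives a 1.1-fold higher number from compound 2 to compound 4 (0.05 log units; within the scatter), the first comparison here of compounds that differ in one place only. At this position of the shared core, the entering group, with its three-membered ring and its hydrogen-bond acceptor, thus leaves the clearance read-out within the scatter of the value for the 4-methylphenyl compound. Nothing measured here bears on why these two values stay so close.

The change alters the aromatic ring and its substituent together, so the part played by each cannot be separated. Also open, on these data alone, is how this position would respond to a more different group, such as a carboxylic acid, an amine or a longer chain.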